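Working notes: amine exchange on compound 1

A few compounds are considered here, and "the series" means these few. Any claim that something is new, unique, unknown or untested is made for them only; others in the source may bear on it.

Measured so far, in an assay on isolated protein for binding affinity to corticotropin-releasing factor receptor 1 (Homo sapiens); on this read-out lower numbers stand for stronger inhibition and higher numbers for weaker inhibition:
compound 1, `CCCN(CC1CC1)c1nc(C)nc(N(CC)c2ccc(N(C)C)cc2C(F)(F)F)n1`, gives 5 nM
compound 2, `CCN(CC)c1cc(C)nc(N(CC)c2c(Cl)cc(OC)cc2Cl)n1`, gives 15 nM
compound 3, `CCN(c1nc(C)cc(C)n1)c1ccc(OC)cc1SC`, gives 60 nM

Compound 1 stands at the lowest number of the three. The nearest is compound 2, whose value lies beyond the scatter from that of compound 1, and the furthest is compound 3, also beyond the scatter. Among the measured compounds shown here, no two of the measured compounds differ in only one place, so no single-point step within the measured set is available; only the three values themselves can be compared.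

The next compound, compound 4, `CCN(CC)c1nc(C)nc(N(CC)c2ccc(N(C)C)cc2C(F)(F)F)n1`, is compound 1 with one change: diethylamino in place of (cyclopropylmethyl)(propyl)amino on an aromatic carbon. The entering group is the same diethylamino that compound 2 carries, though compound 2 sits on a different core, so its value cannot be read as a step. The expectation in this assay is a small loss for compound 4 relative to compound 1, of a size that may or may not clear the scatter, since nothing measured here shows the effect of this exchange directly. The estimated step is a 2.0-fold higher number from compound 1 to compound 4 (0.30 log units; within the scatter). Compound 4 is thus expected to give about 10 nM, within a range of 3 nM to 35 nM.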

Compound 4, inhibition constant: 20 nM
For compound 4 the middle estimate is 2.0-fold (0.30 log units) below the measured one; low and high end bracket the measured number.
By their numbers in this assay, from the lowest: compound 1; then compounds 2 and 4 (each within the scatter of the next); then compound 3.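

In this assay, among the compounds shown here, the exchange of (cyclopropylmethyl)(propyl)amino for diethylamino, on the aromatic carbon between two ring nitrogen atoms, gives a 4.0-fold higher number from compound 1 to compound 4 (0.60 log units; beyond the scatter) and so provides the only single-place step, showing that the number at this position depends on which amine is attached. The entering group has 5 heavy atoms and no ring, against 8 heavy atoms and a three-membered ring in the group that leaves, so the higher number comes with a change in both at once, and this one pair cannot separate them. Nothing measured for these compounds accounts for the step.

On these data alone, it remains open whether the cyclopropylmethyl arm or the propyl arm carries the difference, which a single swap to N-ethyl-N-propylamino or to dipropylamino would help to settle, and whether a cyclic amine such as morpholine would sit closer to compound 1 or to compound 4. Also open, as far as these compounds go, is whether the same exchange gives a step of similar size when the shared core carries a different substituted aromatic ring.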